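Two limits and one open swap

The source may hold more compounds than are shown below. What is called first, only, known or untested is meant among the compounds shown, and "the series" means these compounds.

- compound 1 `O=[N+]([O-])c1cn2c(n1)OC(COc1cccc(-c3ccc(F)nc3F)n1)CC2` gives > 64000 nM as a limit
- compound 2 `CC1(COc2ccc(-c3ccc(F)cc3)cc2)CCn2cc([N+](=O)[O-])nc2O1` gives > 64000 nM as a limit

In an ADME assay on MRC5 cells (Homo sapiens) for cytotoxicity, read by resazurin assay, with a stated time of 72 h (a lower number here means a stronger inhibitor, a higher number a weaker inhibitor), compound 1 stands at the limit of > 64000 nM in this assay, at which 2 of the 2 values shown sit, and has no exact number. Compound 3 `O=[N+]([O-])c1cn2c(n1)OC(COc1cccc(-c3ccc(F)cc3F)n1)CC2` has not yet been measured. It carries 2,4-difluorophenyl in place of 2,6-difluoropyridin-3-yl on an aromatic carbon and keeps the core of compound 1. Going by the values given here, no measured pair shows what this swap does, so no direction is favoured. The expected result is a number no higher from compound 1 to compound 3 (the limit leaves the size open) with nothing beyond the scatter. For compound 3 the estimated value is 64000 nM with an expected range of 30000 nM to 100000 nM in this measurement.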

Compound 3, half-maximal inhibitory concentration: > 64000 nM
Compound 3 gave a limit, no number; the forecaster's own chance of this, stated with the estimate: 75%; the middle value lies on the limit itself.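

Compound 1 and compound 3 both give a limit rather than a number, so no step between them can be read: the limit of > 64000 nM in this assay, at which 3 of the 3 values shown sit.

On these data alone, what putting 2,4-difluorophenyl in place of 2,6-difluoropyridin-3-yl does to the exact value stays open.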